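This account rests on a few compounds, and the source may have more. Where it says the series, first, only, none or still open, it means among the compounds named here.

Measured compounds and values:
- compound 1, `C#Cc1cccc(Nc2ncnc3ccc(NC(=O)Nc4ccc(CN5CCN(C)CC5)cc4)cc23)c1`, in a functional assay on A549 cells (Homo sapiens) for antiproliferative activity, read by MTT assay, with a stated time of 72 h (a higher number here means a weaker inhibitor, a lower number a stronger inhibitor), gives 5170 nM
- compound 2, `O=C(Nc1ccc(CN2CCCC2)cc1)Nc1ccc2ncnc(Nc3cccc(C(F)(F)F)c3)c2c1`, in this assay gives 830 nM

Compound 2 carries the lowest of the two numbers in this assay; its nearest neighbour is compound 1, whose number is higher by an amount beyond the scatter. For the measured compounds named here, the two compounds differ in more than one place, so no single step between them is counted and only the two values themselves are taken as given.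

The next compound in the series is compound 3, `CCN(CC)c1ccc(NC(=O)Nc2ccc3ncnc(Nc4cccc(C(F)(F)F)c4)c3c2)cc1`. Relative to compound 2 the change is diethylamino in place of (pyrrolidin-1-yl)methyl on an aromatic carbon; the rest of the molecule, including the shared core and the trifluoromethyl-bearing aniline, is unchanged.

Going by the values given here, no counted step covers this change, so the expectation rests only on compound 2 and its value 830 nM. The step from compound 2 to compound 3 is expected to be a modest rise, a 1.8-fold higher number from compound 2 to compound 3 (0.26 log units; within the scatter), possibly within the scatter. Compound 3 is therefore estimated at 1500 nM in this assay, with a range from 500 nM to 5000 nM.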

Compound 3, half-maximal inhibitory concentration: 3520 nM
Compound 3: the middle estimate sits 2.3-fold (0.37 log units) below what was measured; the measured number falls inside the stated range.
By their numbers in this assay, from the lowest: compound 2; then compounds 3 and 1 (each within the scatter of the next).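

In this assay, diethylamino in place of (pyrrolidin-1-yl)methyl on the aromatic carbon para to a large group gives a 4.2-fold higher number from compound 2 to compound 3 (0.63 log units; beyond the scatter) with the shared core and the trifluoromethyl-bearing aniline unchanged. For the compounds shown here, this is the first single-place comparison, and it shows that the number responds to the group at this position by more than the scatter. Of the two groups read here, (pyrrolidin-1-yl)methyl carries the lower number, but nothing measured on these compounds accounts for the rise.

On these data alone, the change removes the ring and the carbon link to the aromatic ring together, so their separate contributions stay open; (diethylamino)methyl and pyrrolidin-1-yl at this position would pull them apart. As far as these compounds go, how a morpholin-4-ylmethyl group would read at the same carbon also remains open.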